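This account rests on a few compounds, and the source may have more. Where it says the series, first, only, none or still open, it means among the compounds named here.

Measured so far:
compound 1 `COc1cc(Nc2ncnc3c(NC(=O)Nc4ccc(C)c(C)c4)cccc23)cc(OC)c1` gives 8.8 nM
compound 2 `COc1cc(Nc2ncnc3c(NC(=O)Nc4ccccc4Cl)cccc23)cc(OC)c1` gives 356 nM
compound 3 `COc1cc(Nc2ncnc3c(NC(=O)Nc4cc(F)cc(F)c4)cccc23)cc(OC)c1` gives 2630 nM

These numbers come from a functional assay on RT-112 cells (Homo sapiens) for antiproliferative activity, read by MTT assay, with a stated time of 72 h; a lower number here means a stronger inhibitor of growth, a higher number a weaker inhibitor of growth. Compound 1 stands lowest of the three, at 8.8 nM, making it the strongest growth inhibitor in this small set.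

Compound 4 `COc1cc(Nc2ncnc3c(NC(=O)Nc4ccc(F)cc4C(F)(F)F)cccc23)cc(OC)c1` has not yet been measured. It keeps the core of compound 1 but carries 4-fluoro-2-(trifluoromethyl)phenyl in place of 3,4-dimethylphenyl on an amide-type nitrogen.

Two measured steps make a replacement at the same place. Moving to 2-chlorophenyl gives a 40-fold higher number from compound 1 to compound 2 (1.61 log units; beyond the scatter), and moving to 3,5-difluorophenyl gives a 300-fold higher number from compound 1 to compound 3 (2.48 log units; beyond the scatter). Both are large and point the same way, while the two replacements themselves differ by a 7.4-fold higher number from compound 2 to compound 3 (0.87 log units; beyond the scatter). Among the compounds with values here, no measured compound carries a trifluoromethyl group, so this comparison is only a rough guide.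

A large step towards weaker growth inhibition in this assay is therefore expected. The estimated change is a 68-fold higher number from compound 1 to compound 4 (1.83 log units; beyond the scatter). For compound 4 the estimated value is 600 nM, with an expected range of 100 nM to 3500 nM.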

Compound 4, concentration for 50% growth inhibition: 2970 nM
Compound 4: the middle estimate sits 5.0-fold (0.69 log units) below what was measured; measured number inside the range.
By their numbers in this assay, from the lowest: compound 1; then compound 2; then compounds 3 and 4 (each within the scatter of the next).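

Changing this ring a third time again costs much of the growth inhibition seen with 3,4-dimethylphenyl (a 340-fold higher number from compound 1 to compound 4 (2.53 log units; beyond the scatter)), so all three halogen-bearing rings shown fall well short of compound 1. The two fluorine-bearing rings cannot be told apart, even though 4-fluoro-2-(trifluoromethyl)phenyl has more heavy atoms than 3,5-difluorophenyl (a 1.1-fold higher number from compound 3 to compound 4 (0.05 log units; within the scatter)), while both are weaker than 2-chlorophenyl, as this step shows for the new ring (an 8.3-fold higher number from compound 2 to compound 4 (0.92 log units; beyond the scatter)). Nothing measured here accounts for these differences.

Going by these compounds, it remains open whether both methyl groups of compound 1 are needed, or whether a ring with a single methyl would do as well. Also open, on these data alone, is what a methoxy group or an amine on this ring would give.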